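Replacing phenyl with methyl on an amine chain

The source may hold more compounds than are shown below. What is called first, only, known or untested is meant among the compounds shown, and "the series" means these compounds.

Compound 1 `COc1cc2c(cc1C(C)OCCc1ccccc1)C=CC(C)(C)O2`: 123000 nM
Compound 2 `COc1cc2c(cc1C(C)NCCCc1ccccc1)C=CC(C)(C)O2`: 1080 nM

In an ADME assay on L6 cells (Rattus norvegicus) for cytotoxicity (on this read-out lower numbers stand for stronger inhibition and higher numbers for weaker inhibition), compound 2 has the lower of the two numbers at 1080 nM, while compound 1 lies higher at 123000 nM, a gap well beyond the scatter. For the measured compounds named here, no pair of measured compounds differs in one place only, so no single structural change has yet been measured on its own.

Compound 3 `CCCCNC(C)c1cc2c(cc1OC)OC(C)(C)C=C2` has not yet been measured. It departs from compound 2 by methyl in place of phenyl on a saturated chain carbon, three bonds along the chain from an amine nitrogen. The closer reference is compound 2 at 1080 nM, which also carries the amine. Losing the phenyl is expected to give a moderate move towards a higher number, meaning weaker inhibition, beyond the scatter. The expected size of this move is a 7.4-fold higher number from compound 2 to compound 3 (0.87 log units; beyond the scatter). For compound 3 the estimated value is 8000 nM, with an expected range from 2500 nM to 30000 nM.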

Compound 3, half-maximal inhibitory concentration: 52500 nM
Beside the measured number, compound 3's estimate is 6.6-fold (0.82 log units) below it; measured number above the stated range.
By their numbers in this assay, from the lowest: compound 2; then compound 3; then compound 1.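

In this assay, methyl in place of phenyl on a saturated chain carbon, three bonds along the chain from an amine nitrogen, gives a 49-fold higher number from compound 2 to compound 3 (1.69 log units; beyond the scatter) and so stands as a large step beyond the scatter. For the compounds shown here, this is the first single change that can be read on its own here, and it shows that this place on the amine chain is not indifferent to what it carries: with the shared core and the amine kept, the compound with phenyl has the clearly lower number, meaning stronger inhibition, and the compound with methyl the higher one. No measurement at hand gives a reason for the size of this step.

The compounds shown leave open whether the aromatic ring itself matters here, or whether a cyclohexyl ring or a longer alkyl chain in the same place would keep the lower number. They also leave open whether the same exchange would give a step of similar size on a chain carrying an ether oxygen instead of the amine nitrogen, since compound 1 differs from the others in more than one place.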